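The source may report more compounds than this note shows. Statements on the series, on what has been measured and on what is new or still open speak of the compounds shown alone.

Measured compounds in an ADME assay on HepG2 cells (Homo sapiens) for cytotoxicity, read by luminescence, CellTiter-Glo and ATP content, with a stated time of 72 h; a higher number here means that more compound is needed for the effect, a lower number that less compound is needed:

- compound 1 `c1ccc(Oc2ccc3c(NCCCNCc4ccco4)ccnc3c2)cc1` gives 15200 nM
- compound 2 `COc1cccc(Oc2ccc3c(NCCCNCc4cc(F)ccc4OC)ccnc3c2)c1` gives 7100 nM
- compound 3 `COc1cccc(CNCCCNc2ccnc3cc(Oc4ccc(F)cc4)ccc23)c1O` gives 11000 nM

Compound 1 has the highest of the three numbers in this assay. Its distance to compound 3 is within the scatter, so no order between these two can be read; its distance to compound 2 is beyond the scatter, compound 2 needing less compound for the effect.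

Compound 4 `Fc1ccc(Cc2ccc3c(NCCCNCc4ccco4)ccnc3c2)c(Cl)c1` is the unmeasured analogue of compound 1. The change is 2-chloro-4-fluorobenzyl in place of phenoxy on an aromatic carbon. The group that leaves carries one hydrogen-bond acceptor; the 2-chloro-4-fluorobenzyl that enters carries none, and it sits on the aromatic carbon meta to a fused ring and para to a fused ring.

Going by the values given here, no pair of measured compounds shows this kind of change, so there is no measured step to lean on. Among the compounds with values here, the three numbers so far all sit in a narrow band, and the step from compound 1 to compound 4 is expected to be small, at most slightly downward, close to the scatter: a 1.5-fold lower number from compound 1 to compound 4 (0.18 log units; within the scatter). For compound 4 the estimate in this assay is 10000 nM, with a range from 4000 nM to 30000 nM.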

Compound 4, half-maximal effective concentration: 5730 nM
Estimate against measurement, compound 4: 1.7-fold (0.24 log units) above; the range from low to high includes it.
By their numbers in this assay, from the lowest: compounds 4, 2, 3 and 1 (each within the scatter of the next, the first and the last beyond it).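

In this assay, the aromatic carbon meta to a fused ring and para to a fused ring now has a measured single-place change: 2-chloro-4-fluorobenzyl in place of phenoxy gives a 2.7-fold lower number from compound 1 to compound 4 (0.42 log units; beyond the scatter). This step lies beyond the scatter, so the group at this position can shift the number while the rest of compound 1 stays the same. The exchange removes the hydrogen-bond acceptor of the phenoxy and brings in chlorine and fluorine at once, and no measurement at hand accounts for the step.

The compounds shown do not separate the loss of the phenoxy oxygen from the addition of the two halogens; unsubstituted benzyl at this position would bear on that. On these data alone, how a basic amine or a carboxylic acid on this aromatic carbon would read in this assay also remains open.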